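Removing a methoxy group from an aryl-substituted pyrazolopyridine core

A few compounds are considered here, and "the series" means these few. Any claim that something is new, unique, unknown or untested is made for them only; others in the source may bear on it.

Measured compounds:
Compound 1 `c1ccc(-c2ccnc3c2c(-c2ccccc2)nn3-c2ccccc2)cc1` — 3210 nM
Compound 2 `COc1ccc(-c2ccnc3c2c(-c2ccccc2)nn3-c2ccccc2)cc1` — 6590 nM
Compound 3 `COc1ccc(-c2nc3c(c(-c4ccccc4)nn3-c3ccccc3)c(-c3ccc(N4CCN(C)CC4)cc3)c2C#N)cc1` — 1330 nM

Of the compounds shown here, three have been tested in a functional assay on HepG2 cells (Homo sapiens) for inhibition, read by MTT assay, with a stated time of 48 h; on this read-out lower numbers stand for stronger inhibition and higher numbers for weaker inhibition. Compound 1 `c1ccc(-c2ccnc3c2c(-c2ccccc2)nn3-c2ccccc2)cc1` and compound 2 `COc1ccc(-c2ccnc3c2c(-c2ccccc2)nn3-c2ccccc2)cc1` share a core and differ at one place: hydrogen in place of methoxy on an aromatic carbon. This change gave a 2.1-fold lower number from compound 2 to compound 1 (0.31 log units; beyond the scatter). Compound 3 `COc1ccc(-c2nc3c(c(-c4ccccc4)nn3-c3ccccc3)c(-c3ccc(N4CCN(C)CC4)cc3)c2C#N)cc1` carries a larger, more substituted core; how its core differs from that of compound 2 is not broken down here. In this assay compound 3 gives 1330 nM, the lowest of the three numbers, beyond the scatter from both compound 1 and compound 2.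

Compound 4 `CN1CCN(c2ccc(-c3c(C#N)c(-c4ccccc4)nc4c3c(-c3ccccc3)nn4-c3ccccc3)cc2)CC1` has not yet been measured. It differs from compound 3 in one place: hydrogen in place of methoxy on an aromatic carbon. Within the data shown here, this is the same change as the one from compound 2 to compound 1, made at the same kind of position and on the same kind of ring. Since that earlier step lowered the number in this assay, a step of similar direction and modest size is expected here, resting on compound 2 and compound 1 and their values, with the caution that the core of compound 3 is different and the change has been seen only once. Compound 4 is therefore expected to give 750 nM in this assay, with a likely range from 300 nM to 1900 nM. The expected step from compound 3 to compound 4 is a 1.8-fold lower number from compound 3 to compound 4 (0.25 log units; within the scatter).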

Compound 4, half-maximal inhibitory concentration: 3140 nM
The estimate for compound 4 lay 4.2-fold (0.62 log units) below the measured number; the measured number lies above the stated range.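

In this assay, going from 4-methoxyphenyl to phenyl on the larger core gave a 2.4-fold higher number from compound 3 to compound 4 (0.37 log units; beyond the scatter), so the change did not keep the direction it had on the smaller core. Set side by side, the two steps run opposite ways and lie further apart than their scatter allows: the same change on two cores in this assay, a 2.1-fold lower number (0.31 log units; beyond the scatter) from compound 2 to compound 1 and a 2.4-fold higher number (0.37 log units; beyond the scatter) from compound 3 to compound 4, 4.8-fold (0.69 log units) apart, beyond the scatter of two such steps This shows that, for these two pairs, the result of removing the methoxy group depends on the core that carries it, so a step read on one core could not be carried over to the other; it does not show which part of the core sets the direction, and two pairs give no rule for any further core in the series.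

The compounds shown leave open which of the features of the larger core, the nitrile or the methylpiperazine on its phenyl ring, goes with the reversal, since both are present together in compound 3 and compound 4. They also leave open how another group in place of the methoxy, such as a hydroxyl, a fluorine or an amine, would read on each of the two cores.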